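The compounds below may be only part of what the source reports. "The series", "measured", "known", "first", "only" and "open" are said of these compounds alone.

In a functional assay on MCF7 cells (Homo sapiens) for antiproliferative activity, read by MTT assay, with a stated time of 72 h (on this read-out higher numbers stand for weaker inhibition and lower numbers for stronger inhibition), the three measured compounds of this series are all weak. Compound 1 `CC1=CCC2C(CC[C@@]2(C)O)C(C)(C)C1CC[C@@H]1[C@@]2(C)CCC(=O)C(C)(C)O[C@@H]2CC[C@]1(C)O` gives > 50000 nM, which is a limit of the assay and not a number. Compound 2 `CC1=CC[C@H]2[C@@H]1CC=C(C)[C@@H](CCC1=C(C)CC[C@@H]3OC(C)(C)[C@@H](O)CC[C@@]13C)C2(C)C` likewise gives > 50000 nM, again a limit rather than a number. Among the compounds with values here, compound 3 `CC(=O)O[C@H]1CC[C@]2(C)[C@H](CC[C@@](C)(O)[C@H]2CC[C@@H]2C(C)=CC[C@H]3[C@H](CC[C@]3(C)O)C2(C)C)OC1(C)C` is the only compound with an actual number, 47900 nM, and that number sits just inside (the limit of > 50000 nM in this assay, at which 2 of the 3 values shown sit). Within the data shown here, no pair of measured compounds differs in a single place, so the series carries no measured step to lean on. Compound 4 `CC1=CC[C@H]2[C@H](CC[C@]2(C)O)C(C)(C)[C@@H]1CC[C@H]1[C@]2(C)CC[C@H](OC(=O)c3ccc([N+](=O)[O-])cc3)C(C)(C)O[C@H]2CC[C@@]1(C)O` is not yet measured; it differs from compound 3 by 4-nitrophenyl in place of methyl on a carbonyl carbon. The change is large in size, from acetyl to (4-nitrophenyl)carbonyl, yet nothing measured here tells how the read-out responds to it. The step of a 1.2-fold lower number from compound 3 to compound 4 (0.08 log units; within the scatter) is expected to be none beyond the scatter, with no direction favoured. For compound 4 the estimate is 40000 nM, with a range from 12000 nM to 90000 nM, and a fair chance that only a limit is reported.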

Compound 4, half-maximal inhibitory concentration: 21600 nM
Compound 4: middle estimate off by 1.9-fold (0.27 log units), on the high side, and the stated range covers the measured number.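

With a 2.2-fold lower number from compound 3 to compound 4 (0.35 log units; beyond the scatter) in this assay as the first measured step of the series, the read-out is shown to respond to a change on this carbonyl carbon. The change from acetyl to (4-nitrophenyl)carbonyl is large in size, yet it brings no loss at this place, only a modest gain. Compound 4 gives an actual number rather than a limit, in a series where limits are common: the limit of > 50000 nM in this assay, at which 2 of the 4 values shown sit.

One step does not separate the part played by the aromatic ring from that of the nitro group on it, and a plain phenyl or a 4-aminophenyl in the same place would bear on this. Going by these compounds, whether the same change would act alike on the cores of the other compounds also stays open.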